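The source may report more compounds than this note shows. Statements on the series, on what has been measured and on what is new or still open speak of the compounds shown alone.

Measured compounds in an ADME assay on microsomes from liver (Homo sapiens) for metabolic stability, tested at 2.5 uM; a lower number here means slower removal, a higher number faster removal of the compound:
- compound 1, `O=S(=O)(c1cc(Cl)cc(Cl)c1)c1cnc2cc(F)ccc2c1-c1ccc(Cl)cc1`: 0.13 mL/min
- compound 2, `O=S(=O)(c1cc(Cl)cc(Cl)c1)c1cnc2cc(F)ccc2c1-c1cccc(F)c1`: 0.41 mL/min
- compound 3, `COc1ccc(-c2c(S(=O)(=O)c3cc(Cl)cc(Cl)c3)cnc3cc(F)ccc23)cc1`: 1 mL/min

Compound 2 stands second highest of the three in this assay: compound 3 sits nearest with a 2.4-fold higher number from compound 2 to compound 3 (0.39 log units; beyond the scatter), and compound 1 furthest, the step being a 3.2-fold higher number from compound 1 to compound 2 (0.50 log units; beyond the scatter). The third measured step, a 7.7-fold higher number from compound 1 to compound 3 (0.89 log units; beyond the scatter), links the two outer compounds.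

Compound 4, `N#Cc1cccc(S(=O)(=O)c2cnc3cc(F)ccc3c2-c2cccc(F)c2)c1`, differs from compound 2 in this way: 3-cyanophenyl in place of 3,5-dichlorophenyl on a sulfonyl sulfur. Within the data shown here, none of the measured steps touches the group on the sulfonyl sulfur; all three exchange the aryl group on the aromatic carbon of the shared core. They therefore give only a sense of scale: within this series, single aryl exchanges have moved this assay by modest steps, each beyond the scatter, but none points to a direction for the present change. Given no directional precedent, the expected step of a 1.0-fold lower number from compound 2 to compound 4 (0.01 log units; within the scatter) is set near zero with a wide band. Compound 4 is accordingly estimated at 0.4 mL/min, expected to fall between 0.15 mL/min and 1.2 mL/min.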

Compound 4, intrinsic clearance in a liver preparation (reported as CLH), per the amount of preparation that the assay uses: 0.78 mL/min
Compound 4: the middle estimate sits 2.0-fold (0.29 log units) below what was measured, within the range that was stated.
By their numbers in this assay, from the lowest: compound 1; then compounds 2, 4 and 3 (each within the scatter of the next, the first and the last beyond it).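

Among these compounds, compound 4 gives the first reading at the sulfonyl sulfur in this assay: 3-cyanophenyl in place of 3,5-dichlorophenyl gives a 1.9-fold higher number from compound 2 to compound 4 (0.28 log units; within the scatter), so this exchange cannot be told apart from repeat scatter. With the 3-fluorophenyl group held on the shared core, both chlorine atoms can therefore give way to a nitrile without a step beyond the scatter. No measurement available here explains this result.

Still open, from the compounds shown here alone, is how an amine or a carboxylic acid on the aryl group at the sulfonyl sulfur would read in this assay. Also open, going by these compounds, is whether the 3-cyanophenyl exchange would read the same with the 4-chlorophenyl group of compound 1 or the 4-methoxyphenyl group of compound 3 on the shared core.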